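The source may report more compounds than this note shows. Statements on the series, on what has been measured and on what is new or still open speak of the compounds shown alone.

In an ADME assay on HepG2 2.2.15 cells (Homo sapiens) for cytotoxicity (on this read-out lower numbers stand for higher toxicity in this test and higher numbers for lower toxicity in this test), compound 1 `O=c1[nH]c2ccc(Cl)cc2c(-c2ccccc2Cl)c1CCO` gives 380000 nM and compound 2 `CCC(=O)OCCc1c(-c2ccccc2Cl)c2cc(Cl)ccc2[nH]c1=O` gives 95000 nM. Compound 3 `O=C(OCCc1c(-c2ccccc2Cl)c2cc(Cl)ccc2[nH]c1=O)c1ccc([N+](=O)[O-])cc1` gives 1600000 nM, the highest of the three numbers and so the lowest toxicity in this test. Compound 4 `O=C(/C=C/c1cccc(F)c1)OCCc1c(-c2ccccc2Cl)c2cc(Cl)ccc2[nH]c1=O` has not yet been measured. It differs from compound 3 on a carbonyl carbon, where 2-(3-fluorophenyl)ethenyl stands in place of 4-nitrophenyl: 2-(3-fluorophenyl)ethenyl in place of 4-nitrophenyl on a carbonyl carbon.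

Within the data shown here, three measured steps bear on this change. Replacing the hydrogen on the oxygen of compound 1 moved the number in opposite directions, with a 4.0-fold lower number from compound 1 to compound 2 (0.60 log units; beyond the scatter) for the propanoyl group and a 4.2-fold higher number from compound 1 to compound 3 (0.62 log units; beyond the scatter) for the (4-nitrophenyl)carbonyl group. Among the measured compounds shown here, only one step changes the group at the same place on the carbonyl carbon, and it is large: a 17-fold higher number from compound 2 to compound 3 (1.23 log units; beyond the scatter). For the measured compounds named here, the group on that carbon can therefore matter a great deal in this assay, but no measured compound carries the entering group, so the direction rests on thin evidence. Since compound 3 holds the top number, a move downward toward compound 1 at 380000 nM seems the likelier outcome, of modest size rather than large. The expected change is estimated as a 4.6-fold lower number from compound 3 to compound 4 (0.66 log units; beyond the scatter). The estimated value for compound 4 is 350000 nM, with an expected range from 90000 nM to 1300000 nM.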

Compound 4, half-maximal cytotoxic concentration: > 1600000 nM
Compound 4: a limit, no number; the forecaster's own chance of this, stated with the estimate: 10%; middle value at least 4.5-fold (0.66 log units) from the limit.
By their numbers in this assay, from the lowest: compound 2; then compound 1; then compound 3.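

In this assay the value of compound 4 is a limit of the assay and not a number: the limit of > 1600000 nM in this assay, at which 1 of the 4 values shown sits.

Among these compounds, at this carbonyl carbon, 2-(3-fluorophenyl)ethenyl gives a number no lower from compound 3 to compound 4 (the limit leaves the size open), so 4-nitrophenyl is no longer the only group at the low-toxicity end of the set, and the entering group carries no nitrogen or oxygen atoms. The same carbon also shows an at least 16-fold higher number from compound 2 to compound 4 (1.22 log units; beyond the scatter), and replacing the hydrogen on the oxygen gives an at least 4.2-fold higher number from compound 1 to compound 4 (0.62 log units; beyond the scatter), so both compound 3 and compound 4 sit higher than the parent alcohol, while compound 2, with its propanoyl group, goes against this pattern.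

The size of the step between compound 3 and compound 4 cannot be read, which leaves the order of these two compounds open in this assay. On these data alone, it also remains open whether the ethenyl link, the fluorine or the aromatic ring goes with the high number, a question that a 2-phenylethenyl group without fluorine, or a longer alkyl chain in place of ethyl, would bear on.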